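This account rests on a few compounds, and the source may have more. Where it says the series, first, only, none or still open, it means among the compounds named here.

Three compounds share one core and differ only in the group carried on an aromatic nitrogen: compound 1 `C=CC(=O)Nc1cc(Nc2ncc3ncn(-c4ccc(C)cc4)c3n2)c(OC)cc1N(C)CCN(C)C`, compound 2 `C=CC(=O)Nc1cc(Nc2ncc3ncn(-c4ccc(F)cc4)c3n2)c(OC)cc1N(C)CCN(C)C` and compound 3 `C=CC(=O)Nc1cc(Nc2ncc3ncn(-c4ccc(Cl)cc4Cl)c3n2)c(OC)cc1N(C)CCN(C)C`. In an ADME assay on HT-29 cells (Homo sapiens) for cytotoxicity, read by MTT assay, with a stated time of 72 h (a higher number here means a weaker inhibitor, a lower number a stronger inhibitor), compound 1 gives 9230 nM, compound 2 gives 12000 nM and compound 3 gives 20600 nM. Among the compounds with values here, compound 2 therefore holds the second highest of the three numbers; the step of a 1.3-fold higher number from compound 1 to compound 2 (0.11 log units; within the scatter) and the step of a 1.7-fold higher number from compound 2 to compound 3 (0.23 log units; within the scatter) both stay within the scatter, and only the step of a 2.2-fold higher number from compound 1 to compound 3 (0.35 log units; beyond the scatter) reaches beyond it. Compound 4 `C=CC(=O)Nc1cc(Nc2ncc3ncn(-c4ccc(F)c(Br)c4)c3n2)c(OC)cc1N(C)CCN(C)C` is compound 2 with a single change: bromo in place of hydrogen on an aromatic carbon, which read one bond further out turns 4-fluorophenyl into 3-bromo-4-fluorophenyl. Within the data shown here, the steps that bear on such a change are a 1.3-fold higher number from compound 1 to compound 2 (0.11 log units; within the scatter) and a 1.7-fold higher number from compound 2 to compound 3 (0.23 log units; within the scatter), each small, while the larger step of a 2.2-fold higher number from compound 1 to compound 3 (0.35 log units; beyond the scatter) swapped the whole group for 2,4-dichlorophenyl. Compound 4 is therefore expected to give about 14000 nM in this assay, with a range from 7000 nM to 28000 nM. The expected step of a 1.2-fold higher number from compound 2 to compound 4 (0.07 log units; within the scatter) should stay within the scatter.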

Compound 4, half-maximal inhibitory concentration: 3640 nM
The estimate for compound 4 lay 3.8-fold (0.59 log units) above the measured number; measured number outside the range, below it.
By their numbers in this assay, from the lowest: compound 4; then compounds 1, 2 and 3 (each within the scatter of the next, the first and the last beyond it).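

In this assay, adding one bromo group ortho to the fluoro group gives a 3.3-fold lower number from compound 2 to compound 4 (0.52 log units; beyond the scatter), a step beyond the scatter from a single added heavy atom. Within the data shown here, the earlier compounds showed only that changing the group on the aromatic nitrogen could raise the number, whereas this change lowers it. The steps of a 2.5-fold lower number from compound 1 to compound 4 (0.40 log units; beyond the scatter) and a 5.7-fold lower number from compound 3 to compound 4 (0.75 log units; beyond the scatter) are also beyond the scatter, so compound 4 has the lowest number of the four, and no measurement shown here explains why.

From the compounds shown here alone, it remains open whether this drop is specific to bromo or would also appear with an amine or a nitrile at the same place. Going by these compounds, it is also open whether bromo would have the same effect without the neighbouring fluoro group.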